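A few compounds are considered here, and "the series" means these few. Any claim that something is new, unique, unknown or untested is made for them only; others in the source may bear on it.

Compound 1 `O=C(Nc1ccccc1)c1ccc(-c2ncccc2C(F)(F)F)cc1`: > 4000 nM
Compound 2 `CC(C)(C)c1ccc(NC(=O)c2ccc(-c3ncccc3NC3CCCC3)cc2)cc1`: 190 nM

In a functional assay for antagonist activity at transient receptor potential cation channel subfamily V member 1 (Homo sapiens), read by FLIPR (a lower number here means a stronger inhibitor, a higher number a weaker inhibitor), compound 1 reaches only a limit of the assay, > 4000 nM (the limit of > 4000 nM in this assay, at which 1 of the 2 values shown sits). Compound 2 gives 190 nM in this assay, the only actual number among the two results shown. Compound 3 `CN(C)Cc1cccnc1-c1ccc(C(=O)Nc2ccc(C(C)(C)C)cc2)cc1` differs from compound 2 in one place: (dimethylamino)methyl in place of cyclopentylamino on an aromatic carbon. Among the measured compounds shown here, no measured pair isolates this change, so the expectation rests on compound 2 alone; a loss beyond the usual scatter is expected, the step from compound 2 to compound 3 being estimated at a 4.7-fold higher number from compound 2 to compound 3 (0.68 log units; beyond the scatter). Compound 3 is expected near 900 nM, within 200 nM to 4000 nM.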

Compound 3, half-maximal inhibitory concentration: 746 nM
Compound 3: middle estimate off by 1.2-fold (0.08 log units), on the high side, and the stated range covers the measured number.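

Replacing cyclopentylamino with (dimethylamino)methyl brings a 3.9-fold higher number from compound 2 to compound 3 (0.59 log units; beyond the scatter), a modest loss, and compound 3 still gives a real number rather than a limit, so this position accepts a quite different group. The change removes the five-membered ring and the hydrogen-bond donor together, so their shares in the loss cannot be separated. No measurement shown here explains the loss. Still open, as far as these compounds go, is whether a cyclopentyloxy group or a dimethylamino group placed directly on the aromatic carbon would read closer to compound 2 or to compound 3.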